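Fluorinated nitrophenyl variants of a diaminopyrimidine antifolate series

The compounds below may be only part of what the source reports. "The series", "measured", "known", "first", "only" and "open" are said of these compounds alone.

The set rests on compound 1 `Nc1nc(N)c(CCCN(Cc2ccc(NC(CCC(=O)O)C(=O)O)cc2)c2ccc([N+](=O)[O-])c(F)c2F)c(O)n1`, compound 2 `Nc1nc(N)c(CCCN(Cc2ccc(NC(CCC(=O)O)C(=O)O)cc2)c2cc(F)ccc2[N+](=O)[O-])c(O)n1`, compound 3 `COC(=O)c1ccc(CN(CCCc2c(N)nc(N)nc2O)c2ccc([N+](=O)[O-])c(F)c2F)cc1` and the as yet unmeasured compound 4 `COC(=O)c1ccc(CN(CCCc2c(N)nc(N)nc2O)c2cc(F)ccc2[N+](=O)[O-])cc1`. In a functional assay on CCRF-CEM cells (Homo sapiens) for cytotoxicity, in the absence of a further agent (on this read-out lower numbers stand for stronger inhibition and higher numbers for weaker inhibition), compound 1 gives only a limit, > 100000 nM. Compound 2 likewise gives only a limit in this assay, > 100000 nM. Among the measured compounds shown here, compound 3 is the one compound with a number, giving 41000 nM in this assay.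

The cores of compound 1 and compound 3 differ by methoxycarbonyl in place of (1,3-dicarboxypropyl)amino on an aromatic carbon, and that change brings an at least 2.4-fold lower number from compound 1 to compound 3 (0.38 log units; beyond the scatter). From compound 1 to compound 2 the change is 5-fluoro-2-nitrophenyl in place of 2,3-difluoro-4-nitrophenyl on an amine nitrogen; because both ends sit at the limit of > 100000 nM in this assay, at which 2 of the 3 values shown sit, the step is a step that the two limits leave unreadable from compound 1 to compound 2.

The same change, (5-fluoro-2-nitrophenyl in place of 2,3-difluoro-4-nitrophenyl on an amine nitrogen), leads from compound 3 to compound 4, on a place described in identical words. Since compound 1 and compound 2 give no readable step, the expected step of a 1.2-fold higher number from compound 3 to compound 4 (0.09 log units; within the scatter) is set close to no change. Compound 4 is therefore expected to give about 50000 nM in this assay, within 15000 nM to 150000 nM.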

Compound 4, half-maximal inhibitory concentration: 45000 nM
Compound 4: middle estimate off by 1.1-fold (0.05 log units), on the high side; low and high end bracket the measured number.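

In this assay, 5-fluoro-2-nitrophenyl in place of 2,3-difluoro-4-nitrophenyl brings a 1.1-fold higher number from compound 3 to compound 4 (0.04 log units; within the scatter), but the same exchange on the core of compound 1 cannot be read, so whether it carries from one core to the other stays untested, both ends of that step being limits: the limit of > 100000 nM in this assay, at which 2 of the 4 values shown sit.

Methoxycarbonyl in place of (1,3-dicarboxypropyl)amino brings an at least 2.2-fold lower number from compound 2 to compound 4 (0.34 log units; beyond the scatter), which matches the direction seen with the other aryl group: the same change on two cores in this assay, an at least 2.4-fold lower number (0.38 log units; beyond the scatter) from compound 1 to compound 3 and an at least 2.2-fold lower number (0.34 log units; beyond the scatter) from compound 2 to compound 4; the limit leaves it open whether they differ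

This shows a lower number beyond the scatter with both aryl groups, but it fixes the true size of neither step and rests on these two pairs alone.

The compounds shown leave open how a free carboxylic acid or an amide in place of the methoxycarbonyl would read in this assay. They also leave open the effect of a nitrophenyl group without fluorine, or of a shorter or longer chain on the amine nitrogen.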